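This account rests on a few compounds, and the source may have more. Where it says the series, first, only, none or still open, it means among the compounds named here.

In a functional assay on A549 cells (Homo sapiens) for inhibition, read by MTT assay, with a stated time of 48 h (on this read-out higher numbers stand for weaker inhibition and lower numbers for stronger inhibition), compound 1 `O=C1N/C(=N\Cc2ccc(Cl)cc2)S/C1=C1/CCNC(=O)c2[nH]ccc21` gives > 100000 nM, which is a limit of the assay and not a number. For the measured compounds named here, compound 2 `Cc1ccc(C/N=C2\NC(=O)/C(=C3\CCNC(=O)c4[nH]ccc43)S2)cc1` gives 9080 nM, the only actual number so far. Compound 3 `CC(C)(C)c1ccc(C/N=C2\NC(=O)/C(=C3\CCNC(=O)c4[nH]ccc43)S2)cc1` has tert-butyl in place of methyl on an aromatic carbon. Going by the values given here, the only measured guide is methyl in place of chloro, a large step, an at least 11-fold lower number from compound 1 to compound 2 (1.04 log units; beyond the scatter). It involves different groups, so it sets no direction for this change. In this assay the expected step, a 1.1-fold higher number from compound 2 to compound 3 (0.04 log units; within the scatter), stays within the scatter. Compound 3 is estimated at 10000 nM, with an expected range of 2500 nM to 50000 nM.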

Compound 3, half-maximal inhibitory concentration: 43900 nM
The estimate for compound 3 lay 4.4-fold (0.64 log units) below the measured number; the range from low to high includes it.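

Replacing methyl with tert-butyl on this aromatic carbon is not a neutral swap: in this assay it gives a 4.8-fold higher number from compound 2 to compound 3 (0.68 log units; beyond the scatter), so a change at this one position can raise the number as well as lower it. The value of compound 1 is a limit of the assay and not a number: the limit of > 100000 nM in this assay, at which 1 of the 3 values shown sits.

Even so, tert-butyl in place of chloro gives an at least 2.2-fold lower number from compound 1 to compound 3 (0.35 log units; beyond the scatter), which leaves compound 2 with the lowest number of the three. On these data alone, what a methoxy group or an amine would do on this carbon stays open, as does the effect of a plain hydrogen there.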